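This account rests on a few compounds, and the source may have more. Where it says the series, first, only, none or still open, it means among the compounds named here.

Measured so far:
compound 1 `c1coc(CN2CCN(CCCc3c[nH]c4ccc(-n5cnnc5)cc34)CC2)c1` gives 0.4 nM in an assay on CHO cells for displacement of a labelled ligand from 5-hydroxytryptamine receptor 1D (Homo sapiens); on this read-out higher numbers stand for weaker inhibition and lower numbers for stronger inhibition
compound 2 `CC(=O)Nc1ccc(CN2CCN(CCCc3c[nH]c4ccc(-n5cnnc5)cc34)CC2)cc1` gives 2.5 nM in this assay
compound 3 `CN1CCN(CCCCc2c[nH]c3ccc(-n4cnnc4)cc23)CC1` gives 210 nM in this assay

Compound 2 stands second highest of the three numbers. For the measured compounds named here, the one step between compounds that differ in a single place is a 6.3-fold higher number from compound 1 to compound 2 (0.80 log units; beyond the scatter), so here a change of the group hanging from the ring nitrogen moved the read-out by a modest amount. Going by the values given here, compound 3 differs from compound 2 in more than one place, so no single step links them; its value is simply far higher than that of compound 2.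

Compound 4 `c1cnc(N2CCN(CCCc3c[nH]c4ccc(-n5cnnc5)cc34)CC2)nc1` has not been measured. Compared with compound 2 the change is pyrimidin-2-yl in place of 4-acetamidobenzyl on an amine nitrogen in a ring. Among the compounds with values here, the measured step bearing on it is a 6.3-fold higher number from compound 1 to compound 2 (0.80 log units; beyond the scatter), which shows that swapping the group at this end can shift the number beyond the scatter; no measured step covers a ring placed directly on the ring nitrogen. A modest rise is therefore expected, a 3.2-fold higher number from compound 2 to compound 4 (0.51 log units; beyond the scatter). The estimate for compound 4 in this assay is 8 nM, with a range from 1.5 nM to 40 nM.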

Compound 4, half-maximal inhibitory concentration: 0.6 nM
Beside the measured number, compound 4's estimate is 13-fold (1.12 log units) above it; measured number outside the range, below it.
By their numbers in this assay, from the lowest: compounds 1 and 4 (each within the scatter of the next); then compound 2; then compound 3.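

The ring nitrogen of the shared core can carry a ring directly, with no chain carbon linking the two: pyrimidin-2-yl in place of 4-acetamidobenzyl gives a 4.2-fold lower number from compound 2 to compound 4 (0.62 log units; beyond the scatter) in this assay. For the compounds shown here, this is the first measured case of a ring placed directly on that nitrogen, and the number stays below one of the benzyl-type group in compound 2. Pyrimidin-2-yl in place of (furan-2-yl)methyl gives a 1.5-fold higher number from compound 1 to compound 4 (0.18 log units; within the scatter), so this assay does not separate these two groups, although one has a linking carbon and the other does not.

Going by these compounds, it remains open whether a phenyl or pyridin-2-yl ring set directly on this nitrogen would give a similarly low number, which would indicate how much the two ring nitrogens of pyrimidin-2-yl contribute. Nothing available here explains the drop from compound 2 to compound 4.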